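The compounds below may be only part of what the source reports. "The series", "measured", "known", "first", "only" and "open" are said of these compounds alone.

Measured compounds:
compound 1, `CNC(=O)CCCCCCCn1nc(-c2ccc3oc(N)nc3c2)c2c(N)ncnc21`: 8360 nM
compound 2, `Nc1nc2cc(-c3nn(CCCCCCCCCC(=O)NO)c4ncnc(N)c34)ccc2o1`: > 50000 nM
compound 3, `Nc1nc2cc(-c3nn(CC(=O)NO)c4ncnc(N)c34)ccc2o1`: 27700 nM

All three share one core and differ only in the chain attached to the aromatic nitrogen and in the group at its end. In a functional assay on A549 cells (Homo sapiens) for inhibition, read by MTT assay, with a stated time of 72 h (a lower number here means a stronger inhibitor, a higher number a weaker inhibitor), compound 1 gives 8360 nM. Compound 3, with a hydroxycarbamoyl group directly on the chain carbon bound to the aromatic nitrogen, gives 27700 nM in this assay. For compound 2 this assay reports only a limit, > 50000 nM. Among the two plain numbers compound 3 stands at the higher one, with compound 1 the nearest; the third value is a limit, (the limit of > 50000 nM in this assay, at which 1 of the 3 values shown sits).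

The unmeasured compound 4, `Nc1nc2cc(-c3nn(CCC(=O)NO)c4ncnc(N)c34)ccc2o1`, differs from compound 3 by (hydroxycarbamoyl)methyl in place of hydroxycarbamoyl on a saturated chain carbon bound to an aromatic nitrogen. For the measured compounds named here, two measured steps touch on chain length: a 3.3-fold higher number from compound 1 to compound 3 (0.52 log units; beyond the scatter) and an at least 5.9-fold higher number from compound 1 to compound 2 (0.77 log units; beyond the scatter). Each of them, however, swaps the end group at the same time, so neither reads directly on adding a single chain carbon while keeping the hydroxycarbamoyl end. Cutting the chain away weakened compound 3 modestly; a much longer chain in compound 2 gave only a limit. One extra carbon is therefore expected to move the number little, a 1.4-fold lower number from compound 3 to compound 4 (0.14 log units; within the scatter). Compound 4 is estimated at 20000 nM, within 6000 nM to 60000 nM.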

Compound 4, half-maximal inhibitory concentration: > 150000 nM
Compound 4: only a limit was reported; the forecaster's own chance of this, stated with the estimate: 20%; middle value at least 7.5-fold (0.87 log units) away from the limit.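

In this assay compound 4 is reported only as a limit, > 150000 nM, a reading that sets a bound and not an exact number: the limit of > 150000 nM in this assay, at which 1 of the 4 values shown sits.

Even so, adding one carbon to the chain on the aromatic nitrogen while keeping the hydroxycarbamoyl end, the change from hydroxycarbamoyl to (hydroxycarbamoyl)methyl, gives an at least 5.4-fold higher number from compound 3 to compound 4 (0.73 log units; beyond the scatter), so this small change in chain length alone clearly weakens the result. Set against compound 1, with its longer chain ending in a methylcarbamoyl group, the change reads an at least 17-fold higher number from compound 1 to compound 4 (1.25 log units; beyond the scatter), while the step linking compound 2 and compound 4 cannot be read, with limits on both sides.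

The compounds shown leave open how the number behaves at chain lengths between that of compound 4 and the much longer chain of compound 2, and whether any of those lengths with a hydroxycarbamoyl end comes close to compound 1. They also leave open whether a carboxylic acid or an amine at the end of the short chain would follow the same course as the hydroxycarbamoyl group.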